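Swapping Chloro for Amino on Two Benzyl Purine Isomers

A few compounds are considered here, and "the series" means these few. Any claim that something is new, unique, unknown or untested is made for them only; others in the source may bear on it.

Compound 1 `ClCc1ccccc1Cn1cnc2c(Cl)nc(Cl)nc21` and compound 2 `ClCc1cccc(Cn2cnc3c(Cl)nc(Cl)nc32)c1` are built from the same atoms joined differently; the difference between the two cores is not broken down here. In a functional assay on LOX IMVI cells (Homo sapiens) for cytotoxicity, read by sulforhodamine B assay, with a stated time of 48 h (on this read-out higher numbers stand for weaker inhibition of growth and lower numbers for stronger inhibition of growth), compound 1 gives 150 nM, and compound 2 gives 1690 nM. Compound 3 `Nc1nc(Cl)c2ncn(Cc3ccccc3CCl)c2n1` is compound 1 after one change, (amino in place of chloro on an aromatic carbon), and in this assay compound 3 gives 3890 nM; the step is a 26-fold higher number from compound 1 to compound 3 (1.41 log units; beyond the scatter). Compound 4 `Nc1nc(Cl)c2ncn(Cc3cccc(CCl)c3)c2n1` is compound 2 after the same change, (amino in place of chloro on an aromatic carbon), at a place described in identical words. From compound 2 to compound 4 the step in this assay is expected to be an 18-fold higher number from compound 2 to compound 4 (1.25 log units; beyond the scatter), set beside the earlier one because a 26-fold higher number from compound 1 to compound 3 (1.41 log units; beyond the scatter) was large and rests on a single pair. Compound 4 is estimated at 30000 nM in this assay, spanning 8000 nM to 100000 nM.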

Compound 4, concentration for 50% growth inhibition: 3380 nM
Compound 4: middle estimate off by 8.9-fold (0.95 log units), on the high side; measured number outside the range, below it.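

In this assay the step is a 2.0-fold higher number from compound 2 to compound 4 (0.30 log units; within the scatter), so on this core, putting amino in place of chloro gives a difference that cannot be told from the noise of repeated measurements. The size of the change therefore does not carry over from one core to the other: the same change on two cores in this assay, a 26-fold higher number (1.41 log units; beyond the scatter) from compound 1 to compound 3 and a 2.0-fold higher number (0.30 log units; within the scatter) from compound 2 to compound 4, 13-fold (1.11 log units) apart, beyond the scatter of two such steps. This rests on a single pair for each core, and it does not show why the two cores differ or how the change would behave on a further core.

Still open, going by these compounds, is whether another group at the same place, such as methylamino or methoxy, would give a large step on the core of compound 1 and a small one on the core of compound 2.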